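Compound 4 Replaces the Bromothienyl Ketone with Indolyl

This account rests on a few compounds, and the source may have more. Where it says the series, first, only, none or still open, it means among the compounds named here.

Compound 3 `COc1ccc(-c2cc3ccccc3nc2/C=C/C(=O)c2ccc(Br)s2)cc1` carries the lowest number of the three measured, 520 nM in a functional assay on SK-BR-3 cells (Homo sapiens) for antiproliferative activity, read by XTT assay, with a stated time of 72 h (a higher number here means a weaker inhibitor, a lower number a stronger inhibitor), though all three values lie within the scatter of one another: compound 1 `COc1ccc(-c2cc3ccccc3nc2/C=C/C(=O)c2ccccc2)cc1` gives 700 nM and compound 2 `COc1ccc(-c2cc3ccccc3nc2/C=C/C(=O)c2ccc(F)cc2)cc1` gives 810 nM in this assay. Compound 4 `COc1ccc(-c2cc3ccccc3nc2/C=C/C(=O)c2c[nH]c3ccccc23)cc1` differs from compound 3 by 1H-indol-3-yl in place of 5-bromothiophen-2-yl on a carbonyl carbon. Two measured steps change the same carbonyl-bound aryl group, a 1.3-fold lower number from compound 1 to compound 3 (0.13 log units; within the scatter) and a 1.6-fold lower number from compound 2 to compound 3 (0.19 log units; within the scatter), both within the scatter. The new group is larger than any tried before, but nothing measured points beyond the scatter, and the expected step is only a 1.2-fold higher number from compound 3 to compound 4 (0.06 log units; within the scatter). Compound 4 is therefore estimated at 600 nM, within a range of 250 nM to 1500 nM.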

Compound 4, half-maximal inhibitory concentration: 3450 nM
Compound 4: the middle estimate sits 5.8-fold (0.76 log units) below what was measured, outside the stated range (above it).
By their numbers in this assay, from the lowest: compounds 3, 1 and 2 (each within the scatter of the next); then compound 4.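

In this assay the group on the carbonyl carbon does matter: the change to 1H-indol-3-yl gives a 6.6-fold higher number from compound 3 to compound 4 (0.82 log units; beyond the scatter) and a 4.3-fold higher number from compound 2 to compound 4 (0.63 log units; beyond the scatter) and a 4.9-fold higher number from compound 1 to compound 4 (0.69 log units; beyond the scatter). Phenyl, 4-fluorophenyl and 5-bromothiophen-2-yl had left this position looking indifferent, and compound 4 is the first to separate from them. No measurement shown accounts for the loss. From the compounds shown here alone, whether it follows the hydrogen-bond donor or the added six-membered ring stays open, since 1H-indol-3-yl brings both at once. A naphthyl group on this carbonyl carbon would keep the two rings without the donor.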